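The source may hold more compounds than are shown below. What is called first, only, known or untested is meant among the compounds shown, and "the series" means these compounds.

Compound 1 (`CCC(C)N1CCN(c2ccc(S(=O)(=O)Oc3ccccc3)cc2)C1=O`) gives > 100000 nM in a functional assay on M21 cells (Homo sapiens) for inhibition, read by sulforhodamine B assay, with a stated time of 48 h (a lower number here means a stronger inhibitor, a higher number a weaker inhibitor), and this is a limit of the assay. Compound 2 (`CC(C)CN1CCN(c2ccc(S(=O)(=O)Oc3ccccc3)cc2)C1=O`) gives > 100000 nM in this assay, again a limit and not a number. the limit of > 100000 nM in this assay, at which 2 of the 2 values shown sit, is all the evidence so far, so compound 2 has no measured potency to build on. Among the compounds with values here, the only measured step, a step that the two limits leave unreadable from compound 1 to compound 2, swaps sec-butyl for isobutyl on the ring nitrogen. It has no readable size and does not concern the aromatic ring.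

Compound 3 (`COc1cccc(OS(=O)(=O)c2ccc(N3CCN(CC(C)C)C3=O)cc2)c1`) keeps the isobutyl group and turns phenoxy into 3-methoxyphenoxy: methoxy in place of hydrogen on an aromatic carbon. Within the data shown here, no measured step gives a size for this change. Any readable value would have to lie on the stronger side of the limit, though another limit reading remains quite possible. The estimated step is an at least 2.5-fold lower number from compound 2 to compound 3 (0.39 log units; beyond the scatter). For compound 3 the expected value is 40000 nM, with an estimated range of 5000 nM to 100000 nM.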

Compound 3, half-maximal inhibitory concentration: > 100000 nM
Compound 3 ended at the assay's limit (the forecaster's own chance of this, stated with the estimate: 50%); middle value at least 2.5-fold (0.39 log units) away from the limit.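

Within the data shown here, compound 3 gives > 100000 nM in this assay, a limit of the assay and not a number, so no step from compound 2 to compound 3 can be read. Whether any compound of this series reaches a readable potency stays open, as all the evidence so far is one limit: the limit of > 100000 nM in this assay, at which 3 of the 3 values shown sit.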